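The compounds below may be only part of what the source reports. "The series", "measured", "known", "first", "only" and "open" are said of these compounds alone.

Measured so far:
Compound 1 `CC(F)(F)c1nc([C@@H](O)[C@H](O)[C@H](O)CO)c[nH]1`: 1 h
Compound 2 `OC[C@@H](O)[C@@H](O)[C@H](O)c1c[nH]c(-c2ncon2)n1`: 0.7 h

In an ADME assay on the whole organism (strain 129/SvEvBrd x C57BL/6) for metabolic stability, with Mus musculus as the target (on this read-out higher numbers stand for a longer-lived compound and lower numbers for a shorter-lived compound), compound 2 gives 0.7 h, which lies within the usual scatter of compound 1 at 1 h. The two compounds therefore cannot be told apart on this read-out.

The next compound is compound 3 `Cn1cnc(-c2nc([C@@H](O)[C@H](O)[C@H](O)CO)c[nH]2)c1`, in which 1-methyl-1H-imidazol-4-yl takes the place of 1,2,4-oxadiazol-3-yl on an aromatic carbon, between two ring nitrogen atoms (1-methyl-1H-imidazol-4-yl in place of 1,2,4-oxadiazol-3-yl on an aromatic carbon).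

Within the data shown here, only one measured step bears on this change. It is a 1.4-fold lower number from compound 1 to compound 2 (0.15 log units; within the scatter), and it swaps one group for another on that same carbon. Since that swap stayed within the scatter, no step beyond the scatter is expected here, in either direction. Among the measured compounds shown here, one step is thin evidence, and no measured compound carries the new group.

The expected change is a 1.1-fold higher number from compound 2 to compound 3 (0.06 log units; within the scatter). For compound 3 the estimated half-life is 0.8 h, with an expected range of 0.4 h to 1.6 h.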

Compound 3, half-life: 1.6 h
Estimate against measurement, compound 3: 2.0-fold (0.30 log units) below; the measured number falls inside the stated range.
By their numbers in this assay, from the lowest: compounds 2, 1 and 3 (each within the scatter of the next, the first and the last beyond it).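

In this assay, placing 1-methyl-1H-imidazol-4-yl in place of 1,2,4-oxadiazol-3-yl on the aromatic carbon between two ring nitrogen atoms gives a 2.3-fold higher number from compound 2 to compound 3 (0.36 log units; beyond the scatter) and so shows, modestly, that the group on this carbon can move the half-life beyond the scatter, which the earlier pair did not show. The same new group measured against 1,1-difluoroethyl gives a 1.6-fold higher number from compound 1 to compound 3 (0.20 log units; within the scatter) and leaves compound 1 and compound 3 indistinguishable, so only the two groups at the ends of this small set can be told apart. Nothing measured alongside these half-lives offers an explanation for the step. As far as these compounds go, whether an amine or a carboxylic acid on this carbon would shift the half-life further remains open. So does whether the step seen here would hold on a different core.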